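The source may report more compounds than this note shows. Statements on the series, on what has been measured and on what is new or still open speak of the compounds shown alone.

Of the compounds shown here, three sharing one core have been measured in a physicochemical assay for lipophilicity, measured as octanol-water partition, at pH 7.4; on this read-out lower numbers stand for lower lipophilicity and higher numbers for higher lipophilicity. Compound 1, `Clc1ccc(NC2=NCCC3(CCCCC3)S2)cc1`, gives 2.5 in this assay. Compound 2, `Brc1ccc(NC2=NCCC3(CCCCC3)S2)cc1`, gives 2.53, and compound 3, `CCc1ccc(NC2=NCCC3(CCCCC3)S2)cc1`, gives 2.31. Among these three numbers compound 1 stands second highest, with compound 2 nearest at a number 0.03 log units higher from compound 1 to compound 2 (within the scatter) and compound 3 furthest at a number 0.19 log units lower from compound 1 to compound 3 (within the scatter). The remaining step, a number 0.22 log units lower from compound 2 to compound 3 (within the scatter), is likewise small. All three steps sit within the usual scatter, so the three compounds cannot be ranked against each other on these numbers.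

Compound 4, `CC(=O)c1ccc(NC2=NCCC3(CCCCC3)S2)cc1`, has not yet been measured. It differs from compound 1 as follows: acetyl in place of chloro on an aromatic carbon. Within the data shown here, none of the measured steps involves an acetyl group; they concern swaps among chloro, bromo and ethyl, all of which stayed within the scatter, so they set no direct precedent for this change. The acetyl brings one hydrogen-bond acceptor where the chloro brought none, and on that basis a drop beyond the scatter is expected for compound 4, namely a number 1.20 log units lower from compound 1 to compound 4 (beyond the scatter). Compound 4 is estimated to give about 1.3 in this assay, with a likely range from 0.9 to 1.8.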

Compound 4, distribution coefficient: 1.97
The estimate for compound 4 lay 0.67 log units below the measured number; measured number outside the range, above it.
By their numbers in this assay, from the lowest: compound 4; then compounds 3, 1 and 2 (each within the scatter of the next).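

Chloro, bromo and ethyl could not be told apart in this assay, but acetyl on the same aromatic carbon, para to a large group, moves the number beyond the scatter whichever of them it replaces (a number 0.53 log units lower from compound 1 to compound 4 (beyond the scatter); a number 0.56 log units lower from compound 2 to compound 4 (beyond the scatter); a number 0.34 log units lower from compound 3 to compound 4 (beyond the scatter)). This makes compound 4 the lowest of the four, and shows that this position does respond to a change of group in this assay. Acetyl is also the only one of these four groups that carries a hydrogen-bond acceptor, but no measurement available here ties the drop to that feature or to any other cause.

Going by these compounds, whether the number would fall further or less with a nitrile, an amine or a carboxylic acid at this position remains open. Also unknown is whether acetyl would give a similar step on a different core.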